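The source may hold more compounds than are shown below. What is called first, only, known or untested is meant among the compounds shown, and "the series" means these compounds.

Measured in a functional assay on Ehrlich cells (Mus musculus) for cytotoxicity, read by trypan blue exclusion, with a stated time of 2 h, tested at 100 ug/mL; on this read-out higher numbers stand for a stronger effect at the one concentration tested and lower numbers for a weaker effect:
compound 1 `N#CC1=C(N)N(c2ccc(S(N)(=O)=O)cc2)C2=C(CCCC2)C1c1ccccc1` — 30%
compound 2 `N#CC1=C(N)N(c2ccc(S(N)(=O)=O)cc2)C2=C(CCCC2)C1c1ccccc1O` — 100%
compound 3 `N#CC1=C(N)N(c2ccc(S(N)(=O)=O)cc2)C2=C(CCCC2)C1c1ccc([N+](=O)[O-])cc1` — 20%

Compound 3 gives the lowest of the three numbers; the nearest is a number 10 percentage points lower from compound 1 to compound 3 (within the scatter), within the scatter, and the furthest, a number 80 percentage points lower from compound 2 to compound 3 (beyond the scatter), lies well beyond it. Compound 4 `Cc1ccc(C2C(C#N)=C(N)N(c3ccc(S(N)(=O)=O)cc3)C3=C2CCCC3)o1` is not yet measured. Its change: 5-methylfuran-2-yl in place of 4-nitrophenyl on a saturated ring carbon. Two steps at the same saturated ring carbon bear on it: a number 80 percentage points lower from compound 2 to compound 3 (beyond the scatter), a large one, and a number 10 percentage points lower from compound 1 to compound 3 (within the scatter), within the scatter. Only the hydroxy-bearing compound 2 stands apart beyond the scatter; the phenyl compound 1 and the 4-nitrophenyl compound 3 lie within the scatter of each other. On these data alone, a 5-methylfuran-2-yl group is untested here, so the expected step of a number 15 percentage points higher from compound 3 to compound 4 (beyond the scatter) is small, likely none beyond the scatter, with wide uncertainty. Compound 4 is estimated at 35%, range 10% to 70%.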

Compound 4, a percentage reported as activity, at one concentration (the size of the read-out at that concentration, not a potency): 30%
Compound 4: middle estimate off by 5 percentage points, on the high side; the measured number falls inside the stated range.
By their numbers in this assay, from the lowest: compounds 3, 1 and 4 (each within the scatter of the next); then compound 2.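

In this assay, a 5-methylfuran-2-yl group on the saturated ring carbon does not separate from the groups without hydroxy: a number 10 percentage points higher from compound 3 to compound 4 (within the scatter) and no change at the digits printed from compound 1 to compound 4 (within the scatter) are the steps. A five-membered aromatic ring with 1 hetero atom therefore sits with phenyl and 4-nitrophenyl, while a number 70 percentage points lower from compound 2 to compound 4 (beyond the scatter) leaves only the 2-hydroxyphenyl compound apart. Nothing available explains that gap.

Still open, on these data alone, is whether the number of compound 2 depends on a free hydroxy group in that ring placement. A 4-hydroxyphenyl, 2-methoxyphenyl or 2-aminophenyl group would test this.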